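The source may report more compounds than this note shows. Statements on the series, on what has been measured and on what is new or still open speak of the compounds shown alone.

Compound 2 `Cc1ccc(-c2nc(SCc3cn(CC(=O)NC(=O)Nc4ccccn4)nn3)nc(Nc3cccc(Cl)c3)c2C#N)cc1` shows the highest number of the two measured in a functional assay on B16-F10 cells (Mus musculus) for inhibition, read by MTT assay, with a stated time of 72 h (a higher number here means a weaker inhibitor, a lower number a stronger inhibitor), where compound 2 gives 7580 nM. Compound 1 `CC(C)c1ccc(-c2nc(SCc3cn(CC(=O)NC(=O)Nc4ccccn4)nn3)nc(Nc3cccc(C(F)(F)F)c3)c2C#N)cc1` gives 1700 nM there, a gap beyond the scatter. Compound 3 `Cc1ccc(-c2nc(SCc3cn(CC(=O)NC(=O)Nc4ccccn4)nn3)nc(Nc3cccc(C(F)(F)F)c3)c2C#N)cc1` is not yet measured. It differs from compound 2 by trifluoromethyl in place of chloro on an aromatic carbon, a group that compound 1 also carries. For the measured compounds named here, no measured pair isolates this change, so the expected step of a 2.2-fold lower number from compound 2 to compound 3 (0.34 log units; beyond the scatter) is a moderate fall in number toward compound 1, near the edge of the scatter. Compound 3 is estimated at 3500 nM, within 1500 nM to 8000 nM.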

Compound 3, half-maximal inhibitory concentration: 9580 nM
For compound 3 the middle estimate is 2.7-fold (0.44 log units) below the measured one; measured number outside the range, above it.
By their numbers in this assay, from the lowest: compound 1; then compounds 2 and 3 (each within the scatter of the next).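

In this assay, replacing 3-chlorophenyl with 3-(trifluoromethyl)phenyl gives a 1.3-fold higher number from compound 2 to compound 3 (0.10 log units; within the scatter), so these two groups are not told apart at this position when methyl is held constant. With trifluoromethyl held constant, methyl in place of isopropyl gives a 5.6-fold higher number from compound 1 to compound 3 (0.75 log units; beyond the scatter), so the separation of compound 1 follows the isopropyl site, not the trifluoromethyl. Nothing at hand bears on the reason for either step. From the compounds shown here alone, whether an amine or a methoxy group on that aromatic carbon would differ from chloro and trifluoromethyl remains open, as does whether the isopropyl effect would hold with chloro there.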